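The source may hold more compounds than are shown below. What is called first, only, known or untested is meant among the compounds shown, and "the series" means these compounds.

Of the compounds shown here, three have been measured in a functional assay on MCF7 cells (Homo sapiens) for inhibition, read by MTT assay, with a stated time of 48 h; a lower number here means a stronger inhibitor, a higher number a weaker inhibitor. Compound 1 `C=C1C(=O)N(c2ccccc2)N(C)C1c1ccccc1` gives 84400 nM, compound 2 `C=C1C(=O)N(c2ccccc2)N(c2ccccc2)C1CC` gives 20000 nM, and compound 3 `C=C1CN(C)N(c2ccccc2)C1=O` gives 56000 nM. Among these three numbers compound 3 stands second highest: its nearest neighbour is compound 1, and the gap between them, a 1.5-fold lower number from compound 1 to compound 3 (0.18 log units; within the scatter), lies within the usual scatter of this assay. Compound 2 sits furthest away, with the lower number of the three.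

Compound 4 `C=C1C(=O)N(c2ccccc2)N(C)C1CC` has not been measured. It differs from compound 3 in one place: ethyl in place of hydrogen on a saturated ring carbon. Among the compounds with values here, only one measured step touches the same ring carbon, a 1.5-fold lower number from compound 1 to compound 3 (0.18 log units; within the scatter), where a phenyl group was exchanged for hydrogen with no change beyond the scatter. Compound 2 also carries an ethyl group on that carbon, but it differs from compound 3 in a second place as well, so its lower value cannot be read as the effect of the ethyl group alone.

Taken together, these numbers give little reason to expect a large step in this assay from adding an ethyl group. Compound 4 is therefore estimated at 40000 nM, with a range from 15000 nM to 110000 nM, and the expected step of a 1.4-fold lower number from compound 3 to compound 4 (0.15 log units; within the scatter) stays within the scatter.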

Compound 4, half-maximal inhibitory concentration: 185000 nM
Compound 4: the middle estimate sits 4.6-fold (0.67 log units) below what was measured, and the stated range ends below it.
By their numbers in this assay, from the lowest: compound 2; then compounds 3 and 1 (each within the scatter of the next); then compound 4.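

In this assay the saturated ring carbon proves sensitive to what it carries: ethyl in place of hydrogen gives a 3.3-fold higher number from compound 3 to compound 4 (0.52 log units; beyond the scatter), and ethyl in place of phenyl gives a 2.2-fold higher number from compound 1 to compound 4 (0.34 log units; beyond the scatter), so ethyl leads to a weaker inhibitor than either group, although compounds 1 and 3 lie within the scatter of each other. The group on the amine nitrogen in the ring also counts, since methyl in place of phenyl, with ethyl kept on the carbon, gives a 9.3-fold higher number from compound 2 to compound 4 (0.97 log units; beyond the scatter), the largest of these three steps. Nothing measured here accounts for these steps. On these data alone, only hydrogen, ethyl and phenyl have been compared on that carbon, so it remains open how a methyl group, a longer chain or a carboxylic acid there would compare. As far as these compounds go, it also remains open whether phenyl on the nitrogen gives a similar step when that carbon carries hydrogen.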